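Fluorine removal on the benzylamide in two cores

A few compounds are considered here, and "the series" means these few. Any claim that something is new, unique, unknown or untested is made for them only; others in the source may bear on it.

Measured so far:
compound 1 `O=C(CC1c2ccccc2N=C(SCCCCCN2CCCC2)N1c1ccc(-c2ccc(F)cc2)cc1)NCc1ccc(F)cc1` — 35.1%
compound 2 `O=C(CC1c2ccccc2N=C(SCCCCCN2CCCC2)N1c1ccc(-c2ccc(F)cc2)cc1)NCc1ccccc1` — 68.2%
compound 3 `CN(C)CCCCCSC1=Nc2ccccc2C(CC(=O)NCc2ccc(F)cc2)N1c1ccccc1` — "not active" (no number reported)

In an assay on cells for inhibition of Voltage-dependent T-type calcium channel subunit alpha-1I (Homo sapiens), read by patch clamp, tested at 10 uM (on this read-out lower numbers stand for less inhibition and higher numbers for more inhibition at the one concentration tested (going by the name of the read-out)), compound 1 gives 35.1% and compound 2 gives 68.2%. The step between them is a number 33.1 percentage points higher from compound 1 to compound 2 (beyond the scatter) and the change is hydrogen in place of fluoro on an aromatic carbon. Compound 3 is reported in this assay as "not active" (no number reported), with no number attached. The difference between the core of compound 3 and the core of compound 1 is not broken down here; the two differ in more than one place.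

Compound 4 `CN(C)CCCCCSC1=Nc2ccccc2C(CC(=O)NCc2ccccc2)N1c1ccccc1` is not yet measured. Among the measured compounds shown here, it differs from compound 3 by hydrogen in place of fluoro on an aromatic carbon, which is the same change as the one from compound 1 to compound 2, at the same kind of place.

What is expected for compound 4 rests on one earlier step only, a number 33.1 percentage points higher from compound 1 to compound 2 (beyond the scatter), which was large and went upward. Compound 3 has no number from which to count, and its core differs from the core of compound 1 in a way that is not broken down, so the size of the step cannot simply be carried over. Still, the expectation for compound 4 is an upward move from compound 3 of roughly the same kind, and compound 4 is estimated at 30% in this assay, within 5% to 60%.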

Compound 4, a percentage reported as inhibition, at one concentration (the size of the read-out at that concentration, not a potency): 76%
Compound 4: middle estimate off by 46 percentage points, on the low side, outside the stated range (above it).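

Among the compounds shown here, no step from compound 3 to compound 4 can be read in this assay. For the compounds shown here, only one side carries a number: compound 3 stands as "not active" (no number reported) and compound 4 gives 76% on the same read-out. The compounds shown leave open what size the change from 4-fluorobenzyl to benzyl has on the core of compound 3, and how that core compares with the core of compound 1. Nothing available bears on the cause of this result.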